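Fluoro on the benzoyl ring of compound 1

This account rests on a few compounds, and the source may have more. Where it says the series, first, only, none or still open, it means among the compounds named here.

Compound 1 `CC1(C)c2[nH]nc(NC(=O)c3ccccc3)c2CN1Cc1cc(F)cc(F)c1` stands lowest of the three numbers in an assay on Sf21 cells for inhibition of high affinity nerve growth factor receptor (Homo sapiens), read by HTRF, with a stated time of 30 min, in the presence of a further agent that is not named here (on this read-out higher numbers stand for weaker inhibition and lower numbers for stronger inhibition), where compound 1 gives 190 nM. Compound 2 `CC1(C)c2[nH]nc(NC(=O)c3ccccc3)c2CN1Cc1cccc(F)c1F` gives 200 nM, and the step of a 1.1-fold higher number from compound 1 to compound 2 (0.02 log units; within the scatter) lies within the scatter. Compound 3 `CC1(C)c2[nH]nc(NC(=O)c3ccccc3)c2CN1Cc1ccc(F)c(F)c1` gives 680 nM; here a 3.6-fold higher number from compound 1 to compound 3 (0.55 log units; beyond the scatter) and a 3.4-fold higher number from compound 2 to compound 3 (0.53 log units; beyond the scatter) are modest steps beyond the scatter. Compound 4 `CC1(C)c2[nH]nc(NC(=O)c3ccc(F)cc3)c2CN1Cc1cc(F)cc(F)c1` differs from compound 1 by fluoro in place of hydrogen on an aromatic carbon, on the benzoyl side, para to a large group. Going by the values given here, none of the measured steps touch this ring; all three concern the difluorophenyl on the saturated chain carbon bound to the ring amine nitrogen, so they give no direct guidance. With no comparison to rest on, compound 4 is expected to stay within the scatter of compound 1. The expected step is no change at the digits printed from compound 1 to compound 4 (within the scatter), within the scatter. The estimate for compound 4 is 190 nM, with a range from 80 nM to 450 nM.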

Compound 4, half-maximal inhibitory concentration: 350 nM
Beside the measured number, compound 4's estimate is 1.8-fold (0.27 log units) below it, within the range that was stated.
By their numbers in this assay, from the lowest: compounds 1, 2, 4 and 3 (each within the scatter of the next, the first and the last beyond it).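

In this assay, the benzoyl ring gets its first reading: fluoro in place of hydrogen, para to a large group, gives a 1.8-fold higher number from compound 1 to compound 4 (0.27 log units; within the scatter), so this position accepts the fluoro with the 3,5-difluorophenyl group kept in place. Nothing shown bears on a cause for this reading.

Open, on these data alone, is whether a methoxy group, an amine or a carboxylic acid at this position would stay as close to compound 1. Also open, as far as these compounds go, is whether 4-fluorophenyl reads the same alongside the difluorophenyl groups of compound 2 and compound 3.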